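Swapping the Aryl on the Sulfonyl: an Expected Small Step

The source may report more compounds than this note shows. Statements on the series, on what has been measured and on what is new or still open speak of the compounds shown alone.

Three compounds sharing one core have been measured in a functional assay on PC-3 cells (Homo sapiens) for inhibition; a higher number here means a weaker inhibitor, a lower number a stronger inhibitor:
compound 1 `COc1ccc(C(=O)N2CCN(c3nc(N)c4cc(OC)c(OC)cc4n3)CC2)cc1OC`, 71000 nM;
compound 2 `COc1cc2nc(N3CCN(C(=O)c4cccc5ccccc45)CC3)nc(N)c2cc1OC`, 59000 nM;
compound 3 `COc1cc2nc(N3CCN(S(=O)(=O)c4ccc(Cl)cc4)CC3)nc(N)c2cc1OC`, 23000 nM.

Compound 3 gives the lowest number of the three. The gap to compound 2 and the larger gap to compound 1 both lie beyond the scatter, so compound 3 is the strongest inhibitor among the measured set.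

Compound 4 `COc1cc2nc(N3CCN(S(=O)(=O)c4ccccc4[N+](=O)[O-])CC3)nc(N)c2cc1OC` is not yet measured. It differs from compound 3 in one place: 2-nitrophenyl in place of 4-chlorophenyl on a sulfonyl sulfur.

Within the data shown here, only one measured step resembles this change, the exchange of one aryl group for another on a carbonyl carbon, which gave a 1.2-fold lower number from compound 1 to compound 2 (0.08 log units; within the scatter). That swap of aryl groups on the attached linker moved the number hardly at all. Among the measured compounds shown here, the change from compound 3 to compound 4 is likewise a swap of aryl groups, here on the sulfonyl sulfur, and no measured step shows an aryl exchange at that position. For the measured compounds named here, the expectation therefore rests on the one comparison at hand.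

Compound 4 is expected to give about 23000 nM, within a range from 8000 nM to 65000 nM. The estimated step is then no change at the digits printed from compound 3 to compound 4 (within the scatter), that is, no movement beyond the scatter in either direction.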

Compound 4, half-maximal inhibitory concentration: 35000 nM
Estimate against measurement, compound 4: 1.5-fold (0.18 log units) below, within the range that was stated.
By their numbers in this assay, from the lowest: compounds 3, 4, 2 and 1 (each within the scatter of the next, the first and the last beyond it).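

In this assay, among these compounds, the record shows a 1.5-fold higher number from compound 3 to compound 4 (0.18 log units; within the scatter) when 2-nitrophenyl takes the place of 4-chlorophenyl on a sulfonyl sulfur, so this position now has a measured aryl exchange of its own, where the earlier compounds offered such a step only on a carbonyl carbon. The exchange is not a slight one on paper: 2-nitrophenyl is the larger group by heavy atoms and carries hydrogen-bond acceptors and a double bond outside the aromatic ring that 4-chlorophenyl lacks, yet the two compounds cannot be told apart in this assay. No measurement at hand explains why the two compounds read alike.

The compounds shown carry only aryl groups on the sulfonyl sulfur, so it stays open whether an amine or a carboxylic acid on that aryl ring, or a methyl group or longer alkyl chain in place of the ring, would also leave the number within the scatter. A single step also cannot say whether any group at this place can carry the number far from that of compound 3 at 23000 nM in either direction.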